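A few compounds are considered here, and "the series" means these few. Any claim that something is new, unique, unknown or untested is made for them only; others in the source may bear on it.

In an assay on isolated protein for binding affinity to 5-hydroxytryptamine receptor 1D (Homo sapiens) (on this read-out higher numbers stand for weaker inhibition and lower numbers for stronger inhibition), compound 2, whose structure is `COc1ccccc1-c1cc(C2CCNC2)ccc1Cl`, gives 3.4 nM. For the measured compounds named here, this is the only number available here. The other compound, compound 1, with the structure `CCCN(CCC)Cc1ccc(Cl)c(-c2ccccc2OC)c1`, gives > 10000 nM, which is a limit of the assay and not a number. For compound 1 this is the limit of > 10000 nM in this assay, at which 1 of the 2 values shown sits. Going by the values given here, compound 2 therefore stands alone as the one measurable result, with no measured step in this assay to set a scale.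

Compound 3, with the structure `COc1ccccc1-c1cc(C2CCN(C)C2)ccc1Cl`, has not yet been measured. It differs from compound 2 in one place: methyl in place of hydrogen on an amine nitrogen in a ring. Among the compounds with values here, with no measured pair to lean on, the expectation for the step from compound 2 to compound 3 in this assay is no change beyond the usual scatter, so an expected step of a 1.1-fold lower number from compound 2 to compound 3 (0.05 log units; within the scatter). The inhibition constant of compound 3 is estimated at 3 nM, with a likely range from 0.8 nM to 12 nM.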

Compound 3, inhibition constant: 19 nM
Beside the measured number, compound 3's estimate is 6.3-fold (0.80 log units) below it; the whole stated range lies below it.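

Methyl in place of hydrogen on the amine nitrogen in the five-membered ring gives, in this assay, a 5.6-fold higher number from compound 2 to compound 3 (0.75 log units; beyond the scatter), the first measured step for this position. Since a higher number stands for weaker inhibition, a single added carbon at this nitrogen is enough to weaken the result, yet compound 3 still gives a measurable number, so the methyl does not remove the activity. Nothing measured here explains why this change has this effect.

The compounds shown leave open whether the loss grows with a larger group on this nitrogen, such as an ethyl, a longer chain or a benzyl. They also leave open how an acetyl on this nitrogen, which would turn the amine into an amide, would fare.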